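A few compounds are considered here, and "the series" means these few. Any claim that something is new, unique, unknown or untested is made for them only; others in the source may bear on it.

Measured so far:
compound 1 `COc1cccc(/C=C2\CCC/C(=C\c3cccc(Cl)c3)C2=O)c1OC`: > 20000 nM
compound 2 `COc1cccc(/C=C2\CCC/C(=C\c3ccc(Cl)cc3)C2=O)c1OC`: > 20000 nM
compound 3 `COc1ccc(/C=C2\CCC/C(=C\c3cccc(Cl)c3)C2=O)cc1OC`: 11000 nM

In a functional assay on A549 cells (Homo sapiens) for cytotoxicity, read by MTT assay, with a stated time of 72 h (a lower number here means a stronger inhibitor, a higher number a weaker inhibitor), compound 1 gives > 20000 nM, which is a limit of the assay and not a number. Compound 2 gives > 20000 nM, also a limit. Among the measured compounds shown here, compound 3 gives 11000 nM, the only number among the three. The step that the two limits leave unreadable from compound 1 to compound 2 came from the change (4-chlorophenyl in place of 3-chlorophenyl on a double-bonded chain carbon bound to a double-bonded ring carbon); its size cannot be read because the limit of > 20000 nM in this assay, at which 2 of the 3 values shown sit, is where both values sit. How the core of compound 3 differs from that of compound 1 is not broken down here.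

Compound 4 `COc1ccc(/C=C2\CCC/C(=C\c3ccc(Cl)cc3)C2=O)cc1OC` is not yet measured. It differs from compound 3 by 4-chlorophenyl in place of 3-chlorophenyl on a double-bonded chain carbon bound to a double-bonded ring carbon, the same change as between compound 1 and compound 2. Since that earlier step was unreadable, the step from compound 3 to compound 4 is expected to be small, about a 1.1-fold higher number from compound 3 to compound 4 (0.04 log units; within the scatter). Compound 4 is thus estimated at 12000 nM, expected to lie between 5000 nM and 30000 nM.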

Compound 4, half-maximal inhibitory concentration: 10100 nM
For compound 4 the middle estimate is 1.2-fold (0.07 log units) above the measured one; the range from low to high includes it.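

In this assay, 4-chlorophenyl in place of 3-chlorophenyl gives a 1.1-fold lower number from compound 3 to compound 4 (0.04 log units; within the scatter), so on this core the swap leaves no real difference in the reading. The same swap from compound 1 to compound 2 cannot be read, because both values are limits of the assay and not numbers: the limit of > 20000 nM in this assay, at which 2 of the 4 values shown sit. That leaves one readable case, which shows that the swap made little difference on one core but does not show that it behaves alike on both.

As far as these compounds go, whether an amine or a carboxylic acid in place of the chlorine would shift the reading in this assay remains open. Every compound shown carries a chlorine, so the reading without one is also unknown.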